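This account rests on a few compounds, and the source may have more. Where it says the series, first, only, none or still open, it means among the compounds named here.

Compound 1, `Cc1nc(C(N)=O)c(N)c2c1C(=O)N(Cc1ccccc1)C2=O`: < 5000 nM
Compound 2, `Cc1noc(-c2nc(C)c3c(c2N)C(=O)N(Cc2ccc(C(F)(F)F)cc2)C3=O)n1`: < 5000 nM

In a physicochemical assay for solubility, using the shake flask method, in simulated intestinal fluid, measured as kinetic solubility, with a stated time of 2 h, at 25 degrees C, at pH 6.5 (on this read-out higher numbers stand for higher solubility and lower numbers for lower solubility), compound 1 gives < 5000 nM, which is a limit of the assay and not a number. In this assay compound 2 likewise gives < 5000 nM, again a limit of the assay. Going by the values given here, both values sit at the limit of < 5000 nM in this assay, at which 2 of the 2 values shown sit, so no measured step between them can be stated. Compound 3, `Cc1noc(-c2nc(C)c3c(c2N)C(=O)N(Cc2ccc(C(N)=O)cc2)C3=O)n1`, differs from compound 2 by carbamoyl in place of trifluoromethyl on an aromatic carbon. Among the compounds with values here, with no measured step to rest on, the expected change in this assay from compound 2 to compound 3 is an at least 1.8-fold higher number from compound 2 to compound 3 (0.25 log units; that floor lies within the scatter), towards higher solubility. Compound 3 is estimated at 9000 nM, between 2500 nM and 40000 nM.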

Compound 3, solubility: < 5000 nM
Compound 3 was reported as a limit; the forecaster's own chance of this, stated with the estimate: 35%; middle value at least 1.8-fold (0.25 log units) away from the limit.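

The step from compound 2 to compound 3 cannot be read, since compound 3 also gives a limit of the assay and not a number: the limit of < 5000 nM in this assay, at which 3 of the 3 values shown sit.

Going by these compounds, whether carbamoyl in place of trifluoromethyl changes the read-out in this assay, and by how much, stays open.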